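Swapping benzothiazole for benzoxazole on the ether side chain

This account rests on a few compounds, and the source may have more. Where it says the series, first, only, none or still open, it means among the compounds named here.

Compound 1 `CC(C)(C)Sc1c(CC(C)(C)C(=O)O)n(Cc2ccc(Cl)cc2)c2ccc(OCc3cc4ccccc4cn3)cc12`: > 3000 nM, a limit of the assay
Compound 2 `CC(C)(C)Sc1c(CC(C)(C)C(=O)O)n(Cc2ccc(Cl)cc2)c2ccc(OCc3ccc4cnccc4n3)cc12`: 980 nM
Compound 3 `CC(C)(C)Sc1c(CC(C)(C)C(=O)O)n(Cc2ccc(Cl)cc2)c2ccc(OCc3nc4ccccc4s3)cc12`: 260 nM

These three compounds were tested in a functional assay (blood) for inhibition, with Homo sapiens as the target; a higher number here means a weaker inhibitor, a lower number a stronger inhibitor. Compound 3 gives the lowest number of the set at 260 nM, and its nearest neighbour, compound 2, gives 980 nM. The value of compound 1, > 3000 nM, is a limit and not a number.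

The next compound is compound 4 `CC(C)(C)Sc1c(CC(C)(C)C(=O)O)n(Cc2ccc(Cl)cc2)c2ccc(OCc3nc4ccccc4o3)cc12`, which differs from compound 3 at one place: 1,3-benzoxazol-2-yl in place of 1,3-benzothiazol-2-yl on a saturated chain carbon bound to an oxygen on an aromatic ring. It has 1,3-benzoxazol-2-yl in place of 1,3-benzothiazol-2-yl on a saturated chain carbon bound to an oxygen on an aromatic ring.

Three measured steps changed this same place: an at least 3.0-fold lower number from compound 1 to compound 2 (0.48 log units; beyond the scatter), an at least 11-fold lower number from compound 1 to compound 3 (1.06 log units; beyond the scatter) and a 3.8-fold lower number from compound 2 to compound 3 (0.58 log units; beyond the scatter). All lie beyond the scatter, so this assay clearly responds to this group. None of them, however, exchanges one of these two groups for the other. The new group keeps the ring types of compound 3, so a step smaller than those is expected. Since compound 3 holds the lowest number at 260 nM, any drift is expected to be towards a higher number, probably not beyond the scatter. The expected step is a 1.5-fold higher number from compound 3 to compound 4 (0.19 log units; within the scatter). For compound 4 the estimate is 400 nM, with an expected range from 130 nM to 1200 nM.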

Compound 4, half-maximal inhibitory concentration: 2500 nM
Compound 4: the middle estimate sits 6.3-fold (0.80 log units) below what was measured; measured number outside the range, above it.
By their numbers in this assay, from the lowest: compound 3; then compound 2; then compound 4. At a limit, above all of these: compound 1.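

In this assay this position proves sensitive to a single ring atom: 1,3-benzoxazol-2-yl in place of 1,3-benzothiazol-2-yl, with the same ring types and the same counts of hydrogen-bond donors and acceptors, gives a 9.6-fold higher number from compound 3 to compound 4 (0.98 log units; beyond the scatter). The ring types alone therefore do not secure a low number, as 1,3-benzothiazol-2-yl in compound 3 stands ahead of the group with two six-membered aromatic rings in compound 2, while 1,3-benzoxazol-2-yl gives a 2.6-fold higher number from compound 2 to compound 4 (0.41 log units; beyond the scatter). 1,3-Benzoxazol-2-yl in place of isoquinolin-3-yl gives an at least 1.2-fold lower number from compound 1 to compound 4 (0.07 log units; that floor lies within the scatter). Compound 1 is held at a limit, so this step gives only a floor and no order can be read from it: the limit of > 3000 nM in this assay, at which 1 of the 4 values shown sits.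

The compounds shown do not tell why the sulfur-bearing group and the oxygen-bearing group part so widely, and 1,3-benzothiazol-2-yl is the only group with sulfur among them, so it stays open whether sulfur itself matters or only this one group. On these data alone, how a 1,3-benzimidazol-2-yl or a quinolin-2-yl group would read at this same place, on the saturated chain carbon bound to an oxygen on an aromatic ring, also remains open.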